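Ring-hydroxyl removal at the macrocycle of compound 2

The source may report more compounds than this note shows. Statements on the series, on what has been measured and on what is new or still open speak of the compounds shown alone.

Measured so far:
compound 1 `C=C1CC[C@@H]2CCC3=C(C2(C)C)[C@@](O)(C/C(C)=C/[C@@H](O)C1)OC3=O` – 3.86 ug/mL
compound 2 `C=C1CC[C@@H]2CCC3=C(C(=O)[C@@H](/C(C)=C/C(O)C1)[C@H]3O)C2(C)C` – > 50 ug/mL

In a functional assay on P388 cells (Mus musculus) for cytotoxicity, read by MTT assay, with a stated time of 3 days (a lower number here means that less compound is needed, a higher number that more compound is needed for the effect), compound 1 gives 3.86 ug/mL. Compound 2 yields only a limit in this assay, and for compound 2 the readout is reported as > 50 ug/mL, so no number is known for it. Compound 2 thus stands at the limit of > 50 ug/mL in this assay, at which 1 of the 2 values shown sits, the less active end of the two values shown.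

Compound 3 `C=C1CC/C=C(\C)[C@@H]2C(=O)C3=C(CC[C@@H](CC1)C3(C)C)[C@@H]2O` is not yet measured and differs from compound 2 in one place: hydrogen in place of hydroxy on a saturated ring carbon. Within the data shown here, no measured pair carries this change, so its size and direction in this assay are open. Because compound 2 sits at the limit of > 50 ug/mL in this assay, at which 1 of the 2 values shown sits, there is no number from which a shift could be read, and the expected shift is a number no higher from compound 2 to compound 3 (the limit leaves the size open). Compound 3 is estimated at 50 ug/mL, within 15 ug/mL to 150 ug/mL, with a substantial chance that this assay again reports only a limit.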

Compound 3, concentration for half-maximal effect: > 50 ug/mL
Compound 3 ended at the assay's limit; the forecaster's own chance of this, stated with the estimate: 60%; the middle value sits exactly at the limit.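

In this assay no step can be read from compound 2 to compound 3, because both stand at the same limit: the limit of > 50 ug/mL in this assay, at which 2 of the 3 values shown sit. The compounds shown leave open whether hydrogen in place of hydroxy on a saturated ring carbon shifts the read-out in this assay at all, and in which direction.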